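The source may report more compounds than this note shows. Statements on the series, on what has been measured and on what is new or still open speak of the compounds shown alone.

Compound 1 `COc1cc(-c2cc(/C=C/C(=O)c3ccc(N)cc3)[nH]n2)cc(OC)c1OC`: 95%
Compound 2 `COc1ccc(C(=O)/C=C/c2cc(-c3cc(OC)c(OC)c(OC)c3)n[nH]2)cc1OC`: 92%
Compound 3 `COc1ccc(-c2cc(/C=C/C(=O)c3ccc(N)cc3)[nH]n2)cc1OC`: 98%

Three compounds were measured in a functional assay on MDA-MB-435 cells (Homo sapiens) for cytotoxicity, read by sulforhodamine B assay, with a stated time of 48 h, tested at 0.1 uM; a higher number here means a weaker effect of the compound at the concentration tested, a lower number a stronger effect. Compound 3 `COc1ccc(-c2cc(/C=C/C(=O)c3ccc(N)cc3)[nH]n2)cc1OC` gives 98%. Compound 1 `COc1cc(-c2cc(/C=C/C(=O)c3ccc(N)cc3)[nH]n2)cc(OC)c1OC` differs from compound 3 by methoxy in place of hydrogen on an aromatic carbon, and in this assay compound 1 gives 95%; the step of a number 3 percentage points lower from compound 3 to compound 1 (within the scatter). Compound 2 `COc1ccc(C(=O)/C=C/c2cc(-c3cc(OC)c(OC)c(OC)c3)n[nH]2)cc1OC` gives 92% in this assay; the difference between the core of compound 2 and the core of compound 3 is not broken down here. The step of a number 3 percentage points lower from compound 1 to compound 2 (within the scatter).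

Compound 4 `COc1cc(C(=O)/C=C/c2cc(-c3cc(OC)c(OC)c(OC)c3)n[nH]2)cc(OC)c1OC` has not yet been measured. It differs from compound 2 by methoxy in place of hydrogen on an aromatic carbon, the same change that was made from compound 3 to compound 1, occurring twice among these compounds. Because the earlier step of a number 3 percentage points lower from compound 3 to compound 1 (within the scatter) stayed within the scatter, a step of similar size is expected for compound 4 in this assay, a number 2 percentage points lower from compound 2 to compound 4 (within the scatter). Compound 4 is therefore expected to give about 90%, with a likely range between 80% and 100%.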

Compound 4, a percentage reported as activity, at one concentration (the size of the read-out at that concentration, not a potency): 94%
Beside the measured number, compound 4's estimate is 4 percentage points below it, and the stated range covers the measured number.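

In this assay, methoxy in place of hydrogen on an aromatic carbon gives a number 2 percentage points higher from compound 2 to compound 4 (within the scatter), and set beside the earlier case, the two steps do not differ: the same change on two cores in this assay, a number 3 percentage points lower (within the scatter) from compound 3 to compound 1 and a number 2 percentage points higher (within the scatter) from compound 2 to compound 4, 5 percentage points apart, within the scatter of two such steps

On these two cores, then, the change carries over as a step that stays inside the usual scatter, so neither pair shows it moving the read-out in a way that can be told from repeated measurement. This does not show that the change is without effect in general: it rests on two pairs and on a single concentration, which gives no potency and says nothing about other cores in the series.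

The compounds shown leave open whether another group in the same place, such as a hydroxyl, a fluorine or a longer chain like ethoxy, would give a step beyond the scatter. They also leave open whether the methoxy change would still give so small a step at another concentration.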